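Phosphate in place of hydrogen on the nucleoside arm

This account rests on a few compounds, and the source may have more. Where it says the series, first, only, none or still open, it means among the compounds named here.

Three compounds that share one core have been examined in a functional assay on L1210 cells (Mus musculus) for cytotoxicity; a lower number here means a stronger inhibitor, a higher number a weaker inhibitor. Compound 1 `Cc1c2cc[n+](C)cc2c(C)c2c3c([nH]c12)C=CC(=O)[C@@]31O[C@@H]2[C@H](O1)[C@@H](COP(=O)(O)O)O[C@H]2n1cnc2c(N)ncnc21` reaches only a limit in this assay, > 0.8 uM. Compound 2 `Cc1c2cc[n+](C)cc2c(C)c2c3c([nH]c12)C=CC(=O)[C@@]31O[C@@H]2[C@H](O1)[C@@H](COP(=O)(O)O)O[C@H]2n1cnc2c(O)nc(N)nc21` likewise stops at a limit in this assay, > 1 uM. The step from compound 1 to compound 2, a step that the two limits leave unreadable from compound 1 to compound 2, swaps one fused bicyclic amine group for another and cannot be sized, since both ends are limits. Compound 3 `Cc1c2cc[n+](C)cc2c(C)c2c3c([nH]c12)C=CC(=O)[C@@]31O[C@@H]2[C@H](O1)[C@@H](CO)O[C@H]2n1ccc(=O)[nH]c1=O` also gives only a limit in this assay, > 3 uM. Compound 3 therefore stands nowhere definite among the three: every value shown is a limit, as the lines (the limit of > 0.8 uM in this assay, at which 1 of the 3 values shown sits), the limit of > 1 uM in this assay, at which 1 of the 3 values shown sits, and the limit of > 3 uM in this assay, at which 1 of the 3 values shown sits, record.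

Compound 4 `Cc1c2cc[n+](C)cc2c(C)c2c3c([nH]c12)C=CC(=O)[C@@]31O[C@@H]2[C@H](O1)[C@@H](COP(=O)(O)O)O[C@H]2n1ccc(=O)[nH]c1=O` differs from compound 3 by a group of 4 heavy atoms (3 oxygen, 1 phosphorus; no ring) in place of a hydrogen atom, on an oxygen on a saturated carbon. Going by the values given here, no measured step bears directly on this change, because none of the three values is a number; the only measured step, a step that the two limits leave unreadable from compound 1 to compound 2, concerns the bicyclic amine and is itself unreadable. Compound 1 and compound 2, which carry the same phosphate group, sit at limits, and that is the one hint available.

Compound 4 is therefore expected to stay at a limit as well, with an estimated step that the limit leaves unreadable from compound 3 to compound 4 from compound 3. The estimate for compound 4 is 5 uM, within 1 uM to 30 uM.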

Compound 4, concentration for 50% inhibition: 1.1 uM
Beside the measured number, compound 4's estimate is 4.5-fold (0.66 log units) above it; the measured number falls inside the stated range.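

Compound 4 is the only one of the four compounds shown that gives a number rather than a limit in this assay, and the phosphate group in place of hydrogen, on an oxygen on a saturated carbon, gives an at least 2.7-fold lower number from compound 3 to compound 4 (0.43 log units; beyond the scatter). Compound 3 gives > 3 uM, which is a limit and not a number, so this step sets only a minimum size for the change. Going by these compounds alone, this is the first readable sign that this position affects the cytotoxicity read-out, whereas the steps from compound 1 and from compound 2 to compound 4, like the one from compound 1 to compound 2, cannot be read, so the part played by the group on the saturated ring carbon stays undecided.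

Nothing shown here gives a measured property that would account for the step. Also open, on these data alone, is whether the effect belongs to the phosphate group in particular, or whether a carboxylic acid or an amine on the same arm would lower the number in this assay in the same way.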